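The source may hold more compounds than are shown below. What is called first, only, known or untested is meant among the compounds shown, and "the series" means these compounds.

Working notes on the series. Two cores are in play, each bearing a phenyl group and either a 1H-indol-3-yl or a 3,5-dichlorophenyl group on an amide-type nitrogen in a ring. Compound 1 `CO[C@@H]1CC=C2NN(c3c[nH]c4ccccc34)C(=O)CC[C@]2(c2ccccc2)O1` gives 1110 nM in a functional assay on A549 cells (Homo sapiens) for cytotoxicity, read by sulforhodamine B assay, with a stated time of 48 h; on this read-out lower numbers stand for stronger inhibition and higher numbers for weaker inhibition. Compound 2 `CO[C@@H]1CC=C2NN(c3cc(Cl)cc(Cl)c3)C(=O)CC[C@]2(c2ccccc2)O1` gives 6130 nM in this assay. The change from compound 1 to compound 2 is 3,5-dichlorophenyl in place of 1H-indol-3-yl on an amide-type nitrogen in a ring and its step is a 5.5-fold higher number from compound 1 to compound 2 (0.74 log units; beyond the scatter). Compound 3 `CO[C@@H]1CC=C2N(c3c[nH]c4ccccc34)C(=O)C[C@]2(c2ccccc2)O1` carries the indole on the second core; the difference between the two cores is not broken down here. In this assay compound 3 gives 5200 nM, within the scatter of compound 2 and a weaker number than compound 1.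

Compound 4 `CO[C@@H]1CC=C2N(c3cc(Cl)cc(Cl)c3)C(=O)C[C@]2(c2ccccc2)O1` is not yet measured. It differs from compound 3 by 3,5-dichlorophenyl in place of 1H-indol-3-yl on an amide-type nitrogen in a ring, the same kind of change as from compound 1 to compound 2, though not the same: here the place is a five-membered non-aromatic ring with 1 nitrogen, two ring bonds from the ring atom that bears a fused ring and two ring bonds from the ring atom that bears a phenyl group, whereas in compound 1 it is a seven-membered non-aromatic ring with 2 nitrogen, next to the ring nitrogen, three ring bonds from each. Going by the values given here, a step of similar direction and size is expected, a 4.2-fold higher number from compound 3 to compound 4 (0.63 log units; beyond the scatter), because the only measured instance of this change is a 5.5-fold higher number from compound 1 to compound 2 (0.74 log units; beyond the scatter); the different core widens the uncertainty. The estimate for compound 4 in this assay is 22000 nM, expected between 6000 nM and 70000 nM.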

Compound 4, half-maximal inhibitory concentration: 7530 nM
The estimate for compound 4 lay 2.9-fold (0.47 log units) above the measured number; low and high end bracket the measured number.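

In this assay, 3,5-dichlorophenyl in place of 1H-indol-3-yl on the amide-type nitrogen gives a 1.4-fold higher number from compound 3 to compound 4 (0.16 log units; within the scatter), so this core shows no readable effect of the change. The size of the step seen on the core of compound 1 therefore does not carry over to the core of compound 3, and the two steps differ by more than repeat measurements would account for: the same change on two cores in this assay, a 5.5-fold higher number (0.74 log units; beyond the scatter) from compound 1 to compound 2 and a 1.4-fold higher number (0.16 log units; within the scatter) from compound 3 to compound 4, 3.8-fold (0.58 log units) apart, beyond the scatter of two such steps. This does not yield a rule for either core, since each step rests on a single pair of compounds, and it does not show what sets the two cores apart.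

Still open, from the compounds shown here alone, is how other groups on the amide-type nitrogen in a ring behave on the two cores, for example an amine on a short chain or a carboxylic acid. Going by these compounds, it is also open whether such groups would again give a step on one core and none on the other.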